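The source may hold more compounds than are shown below. What is called first, only, known or untested is meant among the compounds shown, and "the series" means these compounds.

Two compounds carrying the same dithiolane-amide triazole side chain on a coumarin-type core have been examined. Compound 1 `Cc1cc(=O)oc2cc(OCCCn3cc(CNC(=O)CCCCC4CCSS4)nn3)ccc12` gives 74.3% in a functional assay on PC-12 cells (Rattus norvegicus) for cytotoxicity, read by MTT assay, with stated times of 3 h and 2 h, tested at 20 uM (a lower number here means a weaker effect, a higher number a stronger effect of the compound at the concentration tested), while compound 2 `CCOC(=O)c1cc2ccc(OCCCn3cc(CNC(=O)CCCCC4CCSS4)nn3)cc2oc1=O` gives 42.1% in this assay. Compound 2 thus stands lowest of the two, with compound 1 sitting a good deal higher, a gap beyond the usual scatter. Compound 3 `O=C(CCCCC1CCSS1)NCc1cn(CCCOc2ccc3cc(-c4ccccc4)c(=O)oc3c2)nn1` differs from compound 2 in one respect: phenyl in place of ethoxycarbonyl on an aromatic carbon. Within the data shown here, no measured pair shows this change, so its size is open. An upward step from compound 2 to compound 3 of a number 12.9 percentage points higher from compound 2 to compound 3 (beyond the scatter) is expected, resting on compound 1 at 74.3% as the only other point. Compound 3 is estimated at 55%, within 30% to 80%.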

Compound 3, a percentage reported as activity, at one concentration (the size of the read-out at that concentration, not a potency): 27.2%
Beside the measured number, compound 3's estimate is 27.8 percentage points above it, and the stated range ends above it.
By their numbers in this assay, from the lowest: compound 3; then compound 2; then compound 1.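

In this assay, among these compounds, phenyl in place of ethoxycarbonyl on this aromatic carbon, two atoms from the ring oxygen, gives a number 14.9 percentage points lower from compound 2 to compound 3 (beyond the scatter) and is the first measured pair to show that the read-out responds to the group at this position. The all-carbon aromatic ring, with no hydrogen-bond acceptors, thus reads lower here than the ester-bearing ethoxycarbonyl. Nothing at hand bears on what lies behind this step. The compounds shown leave open how a carboxylic acid or a primary amide on this carbon would read, and whether a phenyl carrying a methoxy group would follow the bare phenyl.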